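The source may report more compounds than this note shows. Statements on the series, on what has been measured and on what is new or still open speak of the compounds shown alone.

Measured so far in a functional assay on HT-29 cells (Homo sapiens) for cytotoxicity, read by MTT assay, with a stated time of 72 h; a lower number here means a stronger inhibitor of growth, a higher number a weaker inhibitor of growth:

Compound 1 `CS/C(=N\C(=O)c1csc([N+](=O)[O-])c1)NC(=O)c1csc([N+](=O)[O-])c1` — compound 1 gives 51800 nM
Compound 2 `CS/C(=N\C(=O)c1cc2ccccc2s1)NC(=O)c1cc2ccccc2s1` — compound 2 gives 16800 nM
Compound 3 `O=C(/N=C(/NC(=O)c1csc([N+](=O)[O-])c1)[Se]Cc1ccccc1)c1csc([N+](=O)[O-])c1` — compound 3 gives 9250 nM

Compound 3 is made from compound 1 by one change, (a group of 8 heavy atoms (7 carbon, 1 selenium; one six-membered aromatic ring of carbon only) in place of a group of 2 heavy atoms (1 carbon, 1 sulfur; no ring), on a carbon with a double bond to nitrogen), and the step it produced in this assay is a 5.6-fold lower number from compound 1 to compound 3 (0.75 log units; beyond the scatter). The difference between the core of compound 1 and the core of compound 2 is not broken down here; their values alone show compound 2 with the lower number of the two. Compound 2 and compound 3 lie within the usual scatter of each other, so no order is drawn between them.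

Compound 4 `O=C(/N=C(/NC(=O)c1cc2ccccc2s1)[Se]Cc1ccccc1)c1cc2ccccc2s1` is not yet measured. It stands to compound 2 as compound 3 stands to compound 1: the change is a group of 8 heavy atoms (7 carbon, 1 selenium; one six-membered aromatic ring of carbon only) in place of a group of 2 heavy atoms (1 carbon, 1 sulfur; no ring), on a carbon with a double bond to nitrogen, on the same kind of carbon in both pairs, and in the same words, so it counts as the same change. Among the compounds with values here, the expected step in this assay is a 4.2-fold lower number from compound 2 to compound 4 (0.62 log units; beyond the scatter), set a little smaller than the one seen from compound 1 to compound 3, because that single observation a 5.6-fold lower number from compound 1 to compound 3 (0.75 log units; beyond the scatter) rests on one pair only and the core of compound 2 differs in an unbroken-down way. Compound 4 is therefore estimated at 4000 nM, with a likely range from 1500 nM to 12000 nM.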

Compound 4, concentration for 50% growth inhibition: 6510 nM
Estimate against measurement, compound 4: 1.6-fold (0.21 log units) below; the measured number falls inside the stated range.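

In this assay, exchanging methylsulfanyl for the selenium-bearing group with its six-membered aromatic ring, on a carbon with a double bond to nitrogen, gives a 2.6-fold lower number from compound 2 to compound 4 (0.41 log units; beyond the scatter). The change lowers the number on both cores, and the two steps cannot be told apart in size: the same change on two cores in this assay, a 5.6-fold lower number (0.75 log units; beyond the scatter) from compound 1 to compound 3 and a 2.6-fold lower number (0.41 log units; beyond the scatter) from compound 2 to compound 4, 2.2-fold (0.34 log units) apart, within the scatter of two such steps. This supports carrying the change between these two cores as a step of similar size, but two pairs show nothing about other cores, and the exchange of sulfur for selenium and the gain of the aromatic ring arrive together, so neither can be credited with the step on its own.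

Still open, on these data alone, is how far a benzyl group on sulfur or a methyl group on selenium would reproduce the step, which would separate the two parts of the change. Also open, as far as these compounds go, is how an amine or a longer alkyl chain in the same place on that carbon would compare.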